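Trimethoxybenzylidene hydrazide series: cytotoxicity notes, compound 3 pending

The source may report more compounds than this note shows. Statements on the series, on what has been measured and on what is new or still open speak of the compounds shown alone.

Measured so far:
compound 1 `COc1cc(/C=N/NC(=O)c2ccc(-c3ccc(Cl)cc3)nc2C)cc(OC)c1OC`: 41.1 ug/mL
compound 2 `COc1cc(/C=N/NC(=O)c2ccc(-c3cccc(Cl)c3)nc2C)cc(OC)c1OC`: 495 ug/mL

In an ADME assay on WI-38 cells (Homo sapiens) for cytotoxicity, read by colorimetric assay and crystal violet staining, with a stated time of 24 h (a lower number here means a stronger inhibitor, a higher number a weaker inhibitor), compound 1 gives 41.1 ug/mL and compound 2 gives 495 ug/mL. For the measured compounds named here, compound 2 stands highest of the two numbers; its only neighbour is compound 1, and the step of a 12-fold higher number from compound 1 to compound 2 (1.08 log units; beyond the scatter) is large and beyond the scatter. Going by the values given here, that step concerns the chlorine position on the aryl ring and is the only measured step in the set.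

Compound 3 `COc1ccc(/C=N/NC(=O)c2ccc(-c3cccc(Cl)c3)nc2C)cc1OC` differs from compound 2 as follows: hydrogen in place of methoxy on an aromatic carbon. Among the compounds with values here, no measured step touches the methoxy groups, so the step from compound 1 to compound 2 gives no direct guide to this change. With nothing to rest on, no step beyond the scatter is expected in this assay: the estimated step of a 1.1-fold lower number from compound 2 to compound 3 (0.04 log units; within the scatter) is kept near zero with a wide range. Compound 3 is therefore expected to give about 450 ug/mL, between 140 ug/mL and 1400 ug/mL.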

Compound 3, half-maximal inhibitory concentration: 168 ug/mL
Beside the measured number, compound 3's estimate is 2.7-fold (0.43 log units) above it; the measured number falls inside the stated range.
By their numbers in this assay, from the lowest: compound 1; then compound 3; then compound 2.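

In this assay, the methoxy groups now have a measured step of their own: hydrogen in place of methoxy gives a 2.9-fold lower number from compound 2 to compound 3 (0.47 log units; beyond the scatter). Substitution at this position, ortho to a methoxy group and meta to a large group, therefore moves the number beyond the scatter, so the position of the chlorine is no longer the only measured change that does so, although this step is smaller than a 12-fold higher number from compound 1 to compound 2 (1.08 log units; beyond the scatter). No measurement on hand accounts for the lower number.

The compounds shown leave open whether another group at this position, such as a hydroxyl or an ethoxy group, would give a number nearer that of compound 2 or that of compound 3. They also leave open whether the same replacement would produce a step of similar size with the 4-chlorophenyl group of compound 1.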